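This account rests on a few compounds, and the source may have more. Where it says the series, first, only, none or still open, it means among the compounds named here.

Of the compounds shown here, three with the shared core have been measured in an ADME assay on microsomes from liver (Rattus norvegicus) for metabolic stability (a lower number here means that the compound disappears faster, a higher number that the compound lasts longer), differing only in one group on an aromatic carbon of a five-membered aromatic ring with 1 sulfur. Compound 1 `CC#C[C@@H](Cc1nnn[nH]1)c1ccc(OCc2ccc3sc(C)c(-c4ccc(OCCOC)cc4C)c3c2)cc1`, with methyl, gives 0.117 h. Compound 2 `CC#C[C@@H](Cc1nnn[nH]1)c1ccc(OCc2ccc3scc(-c4ccc(OCCOC)cc4C)c3c2)cc1`, with hydrogen, gives 0.217 h. Compound 3 `CC#C[C@@H](Cc1nnn[nH]1)c1ccc(OCc2ccc3sc(F)c(-c4ccc(OCCOC)cc4C)c3c2)cc1`, with fluoro, gives 0.35 h. Among the compounds with values here, compound 3 is separated from the methyl compound alone, as the only step beyond the scatter is a 3.0-fold higher number from compound 1 to compound 3 (0.48 log units; beyond the scatter). The other two steps do not separate their compounds: a 1.6-fold higher number from compound 2 to compound 3 (0.21 log units; within the scatter), and a 1.9-fold higher number from compound 1 to compound 2 (0.27 log units; within the scatter).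

The next structure is compound 4 `CC#C[C@@H](Cc1nnn[nH]1)c1ccc(OCc2ccc3sc(C(F)(F)F)c(-c4ccc(OCCOC)cc4C)c3c2)cc1`. The change is trifluoromethyl in place of fluoro on an aromatic carbon, next to the ring sulfur. Within the data shown here, no measured step makes this replacement, so the three steps at this carbon are the only guide. The largest of them is modest, and the data do not show whether trifluoromethyl would behave more like fluoro or more like methyl. From the compounds shown here alone, the estimated change is a 1.2-fold lower number from compound 3 to compound 4 (0.07 log units; within the scatter), so no step beyond the scatter is expected, and its direction remains open. For compound 4 the expected half-life is 0.3 h, with an estimated range from 0.15 h to 0.6 h.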

Compound 4, half-life: > 3 h
Compound 4: only a limit was reported; the forecaster's own chance of this, stated with the estimate: 2%; middle value at least 10-fold (1.00 log units) from the limit.
By their numbers in this assay, from the lowest: compounds 1, 2 and 3 (each within the scatter of the next, the first and the last beyond it). At a limit, above all of these: compound 4.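

Compound 4 gives > 3 h in this assay, and this is a limit of the assay and not a number: the limit of > 3 h in this assay, at which 1 of the 4 values shown sits. Methyl, hydrogen and fluoro on this aromatic carbon, next to the ring sulfur, produced only one step beyond the scatter, yet the single replacement of fluoro by trifluoromethyl gives an at least 8.5-fold higher number from compound 3 to compound 4 (0.93 log units; beyond the scatter). Measured against the other two groups, the change is large, with an at least 13-fold higher number from compound 2 to compound 4 (1.14 log units; beyond the scatter) and an at least 25-fold higher number from compound 1 to compound 4 (1.40 log units; beyond the scatter), so the group at this carbon can move the half-life much further than compounds 1, 2 and 3 alone showed.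

The compounds shown leave open whether a chloro, a nitrile or a tert-butyl group on this carbon would behave like trifluoromethyl or stay close to methyl, hydrogen and fluoro, and they do not show what sets trifluoromethyl apart. From the compounds shown here alone, how far compound 4 lies past its limit also remains unknown, so the full size of each of these three steps is not established.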